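This account rests on a few compounds, and the source may have more. Where it says the series, first, only, none or still open, it means among the compounds named here.

Measured so far in a functional assay on MCF7 cells (Homo sapiens) for cytotoxicity, read by MTT assay, with a stated time of 72 h; a lower number here means a stronger inhibitor, a higher number a weaker inhibitor:

Compound 1 `CN1CCN(CCCOc2c(OCc3ccccc3)cc(O)c3c(=O)cc(-c4ccccc4)oc23)CC1`: 1020 nM
Compound 2 `O=c1cc(-c2ccccc2)oc2c(OCCCCN3CCCC3)c(OCc3ccccc3)cc(O)c12`: 1890 nM
Compound 3 `CN1CCN(CCCCOc2c(OCc3ccccc3)cc(O)c3c(=O)cc(-c4ccccc4)oc23)CC1`: 2930 nM

Compound 3 carries the highest number of the three. Against compound 1 the step of a 2.9-fold higher number from compound 1 to compound 3 (0.46 log units; beyond the scatter) is beyond the scatter, whereas a 1.6-fold higher number from compound 2 to compound 3 (0.19 log units; within the scatter) is within it, and a 1.9-fold higher number from compound 1 to compound 2 (0.27 log units; within the scatter) likewise.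

Compound 4 `CN1CCN(CCCCOc2c(OCc3ccc(C#N)cc3)cc(O)c3c(=O)cc(-c4ccccc4)oc23)CC1` differs from compound 3 by cyano in place of hydrogen on an aromatic carbon. All three measured steps concern the amine end of the chain, not the benzyloxy group, so none of them bears on this change. No direction can be taken from the data; the default is no step beyond the scatter in this assay.

Compound 4 is therefore expected at 3000 nM, with a range from 1200 nM to 7500 nM. The expected step is a 1.0-fold higher number from compound 3 to compound 4 (0.01 log units; within the scatter), estimated to fall within the scatter.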

Compound 4, half-maximal inhibitory concentration: 2420 nM
The estimate for compound 4 lay 1.2-fold (0.09 log units) above the measured number; the measured number falls inside the stated range.
By their numbers in this assay, from the lowest: compounds 1, 2, 4 and 3 (each within the scatter of the next, the first and the last beyond it).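

In this assay, the benzyloxy end of the series now has its first reading: cyano in place of hydrogen on this aromatic carbon gives a 1.2-fold lower number from compound 3 to compound 4 (0.08 log units; within the scatter). The earlier steps shown here covered only the amine end of the chain, whereas this one shows that benzyl to 4-cyanobenzyl leaves the number within the scatter with the 4-methylpiperazin-1-yl butyl-length chain of compound 3 in place. No measurement available here bears on why this is so.

Still open, on these data alone, is whether a carboxylic acid, a methoxy group or a chlorine at this carbon would stay within the scatter. Also open, as far as these compounds go, is whether cyano gives a similar step on the chain of compound 1 or with the pyrrolidin-1-yl amine of compound 2.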